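Two thioether chains on one core: trimming back to chloro

The source may report more compounds than this note shows. Statements on the series, on what has been measured and on what is new or still open speak of the compounds shown alone.

Compound 1 `OCC#CCSc1cnc2ccccc2c1SCC#CCCl` carries two sulfur-linked chains on the shared core, one ending in a hydroxyl and one ending in a chlorine. Among the measured compounds shown here, in a functional assay on P388 cells (Mus musculus) for antiproliferative activity, with a stated time of 72 h (on this read-out higher numbers stand for weaker inhibition and lower numbers for stronger inhibition), compound 1 gives 5.1 ug/mL, the lowest of the two numbers measured so far. Compound 2 `O=C(/C=C/c1ccccc1)OCC#CCSc1cnc2ccccc2c1Cl` keeps a chloro on the core in place of the second chain and carries a cinnamate ester on the hydroxyl; in this assay compound 2 gives 32.8 ug/mL, a higher number than compound 1 by a gap that lies beyond the scatter. Compound 2 differs from compound 1 in two places, so its value alone does not separate the two changes.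

Compound 3 `OCC#CCSc1cnc2ccccc2c1Cl` is compound 1 with the change (one chlorine atom in place of a group of 6 heavy atoms (4 carbon, 1 sulfur, 1 chlorine; no ring), on an aromatic carbon). The change sits on an aromatic carbon of the six-membered ring with one nitrogen, ortho to a fused ring and opposite the ring nitrogen. For the measured compounds named here, no measured pair isolates this change. Given that compound 2 gives 32.8 ug/mL with a chloro at this carbon, a step toward a higher number is expected for compound 3, with a 2.4-fold higher number from compound 1 to compound 3 (0.37 log units; beyond the scatter) as the estimated size. Compound 3 is therefore expected near 12 ug/mL, within a range from 4 ug/mL to 35 ug/mL.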

Compound 3, concentration for 50% inhibition: 2.4 ug/mL
Estimate against measurement, compound 3: 5.0-fold (0.70 log units) above; the whole stated range lies above it.
By their numbers in this assay, from the lowest: compound 3; then compound 1; then compound 2.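

In this assay, the step from the group of 6 heavy atoms to chloro on this aromatic carbon is a 2.1-fold lower number from compound 1 to compound 3 (0.33 log units; beyond the scatter), so the longer chain with its terminal chlorine is not required at this position for a low number, and the single chlorine atom serves at least as well there. Compound 2 and compound 3 both carry chloro at this carbon and differ only at the hydroxyl, which compound 2 has as a cinnamate ester; in this assay compound 3 gives 2.4 ug/mL and compound 2 gives 32.8 ug/mL, so chloro at this carbon does not by itself go with the higher number of compound 2. Nothing available on these compounds accounts for the direction of the step.

The compounds shown leave open how this carbon reads with an amine or a methoxy group in place of chloro, and whether a thioether chain shorter than the group of 6 heavy atoms would fall with compound 1 or with compound 3. They also leave open how a free amine or a carboxylic acid would read in place of the hydroxyl on the remaining chain.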